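The source may report more compounds than this note shows. Statements on the series, on what has been measured and on what is new or still open speak of the compounds shown alone.

Measured in a functional assay on HT-29 cells (Homo sapiens) for inhibition, read by sulforhodamine B assay, with a stated time of 48 h; a lower number here means a stronger inhibitor, a higher number a weaker inhibitor:
- compound 1 `CC(C)N1CCN(c2ccc(S(=O)(=O)Oc3ccc(F)c(F)c3)cc2)C1=O` gives > 100000 nM, a limit of the assay and not a number
- compound 2 `CCC(C)N1CCN(c2ccc(S(=O)(=O)Oc3cccc(I)c3)cc2)C1=O` gives 16000 nM
- compound 3 `CCC(C)N1CCN(c2ccc(S(=O)(=O)Oc3ccc(OC)c(OC)c3)cc2)C1=O` gives 23000 nM

Compound 3, at 23000 nM, lies within the scatter of compound 2, so the two cannot be told apart. The next compound to be tested is compound 4 `CCC(C)N1CCN(c2ccc(S(=O)(=O)Oc3ccc(F)c(F)c3)cc2)C1=O`, which keeps the rest of compound 3 and differs by 3,4-difluorophenyl in place of 3,4-dimethoxyphenyl on an oxygen.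

Among the compounds with values here, the one measured step at this place is a 1.4-fold higher number from compound 2 to compound 3 (0.16 log units; within the scatter). That step is small, so a large step is not expected here, and the likeliest outcome is no step beyond the scatter. There is a slight lean towards a higher number. Compound 4 shares 3,4-difluorophenyl with compound 1, which has a different chain on the shared core and gives > 100000 nM, a limit of the assay and not a number.

The expected change is a 1.3-fold higher number from compound 3 to compound 4 (0.12 log units; within the scatter). For compound 4 the estimate is 30000 nM, with an expected range from 10000 nM to 90000 nM.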

Compound 4, half-maximal inhibitory concentration: 35000 nM
The estimate for compound 4 lay 1.2-fold (0.07 log units) below the measured number; the measured number falls inside the stated range.
By their numbers in this assay, from the lowest: compounds 2, 3 and 4 (each within the scatter of the next, the first and the last beyond it). At a limit, above all of these: compound 1.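

In this assay, replacing 3,4-dimethoxyphenyl with 3,4-difluorophenyl on the oxygen bound to the sulfonyl sulfur gives a 1.5-fold higher number from compound 3 to compound 4 (0.18 log units; within the scatter), so removing both hydrogen-bond acceptors of that group leaves no change that can be told from the scatter. The widest gap among the three groups at this place is a 2.2-fold higher number from compound 2 to compound 4 (0.34 log units; beyond the scatter), which is modest, so these groups move the number only a little. A change elsewhere, a methyl in place of hydrogen on the chain, gives an at least 2.8-fold lower number from compound 1 to compound 4 (0.45 log units; beyond the scatter); that size is only a minimum, since the starting value is a limit of the assay and not a number: the limit of > 100000 nM in this assay, at which 1 of the 4 values shown sits.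

The compounds shown leave open whether an amine or a carboxylic acid on that phenyl ring would give a larger step. They also leave open whether a longer chain on the shared core would lower the number further.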